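The compounds below may be only part of what the source reports. "The series", "measured", "known", "first", "only" and "open" are said of these compounds alone.

Compound 1, `CC1=C(O)/C(=C/[C@H](C)CCC/C(C)=C/CCc2coc(Cc3ccoc3)c2)OC1=O`, and compound 2, `CC1=C(O)/C(=C\[C@H](C)CC/C=C(/C)CCCc2coc(Cc3ccoc3)c2)OC1=O`, were both tested in a functional assay on A549 cells (Homo sapiens) for cytotoxicity; a higher number here means that more compound is needed for the effect, a lower number that less compound is needed. In this assay compound 1 gives 3.72 ug/mL. In this assay compound 2 gives 3.8 ug/mL; of the two numbers shown this is the upper one, but its gap to compound 1 lies within the usual scatter of repeated measurements, so the two compounds cannot be told apart on these data. Compound 3, `CC1=C(O)/C(=C/[C@H](C)CC/C=C(/C)CCCc2coc(Cc3ccoc3)c2)OC1=O`, has not yet been measured. Set against compound 2 the change is this: the two compounds have the same atoms and bonds and differ only in configuration as drawn: 1 of 3 stereo elements differ; a double bond is drawn E in compound 2 and Z in compound 3. Among the measured compounds shown here, no pair of measured compounds here differs in only one place, so there is no measured step to lean on for a change of this kind. Since compound 1 gives 3.72 ug/mL and compound 2 gives 3.8 ug/mL, the two measured numbers sit close together, and the expected step from compound 2 to compound 3 is a 1.1-fold higher number from compound 2 to compound 3 (0.02 log units; within the scatter), a shift no larger than the scatter and in no definite direction. Compound 3 is therefore estimated at 4 ug/mL in this assay, with a range from 2 ug/mL to 8 ug/mL.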

Compound 3, concentration for half-maximal effect: 3.8 ug/mL
The estimate for compound 3 lay 1.1-fold (0.02 log units) above the measured number, and the stated range covers the measured number.
By their numbers in this assay, from the lowest: compounds 1, 2 and 3 (each within the scatter of the next).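

In this assay, among the compounds shown here, turning a double bond from E to Z gives no change at the digits printed from compound 2 to compound 3 (within the scatter), and this is the first measured step here for a change of this kind. The earlier compounds shown here offered no pair differing in one place, so the expectation for this double bond had no direct measurement behind it; now one pair shows that its drawn geometry can be reversed without a change in this cytotoxicity read-out beyond the scatter of repeated measurements. The comparison is a clean one, as nothing else separates the pair: the fact that compounds 2 and 3 differ only in the configuration as drawn

This single pair cannot show whether the double bond's geometry would remain without consequence once other parts of the molecule are altered, for example if the hydroxyl group on the shared core gave way to a methoxy group, or if the chain carrying the double bond became a longer chain. Nor can it show whether an amine or a carboxylic acid placed on that chain would leave the read-out just as unchanged between the E and Z forms.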